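Three Hydrazone Ureas Measured, a Dibromo Hydroxyphenyl Analogue Awaited

The source may report more compounds than this note shows. Statements on the series, on what has been measured and on what is new or still open speak of the compounds shown alone.

Three compounds have so far been tested in a functional assay on A549 cells (Homo sapiens) for antiproliferative activity, read by MTT assay, with a stated time of 72 h; a lower number here means a stronger inhibitor, a higher number a weaker inhibitor:

compound 1, `O=C(N/N=C/c1ccccc1)Nc1ccc(Oc2ccnc3[nH]ccc23)c(F)c1`, gives 2500 nM
compound 2, `O=C(N/N=C/c1cccc([N+](=O)[O-])c1)Nc1ccc(Oc2ccnc3[nH]ccc23)c(F)c1`, gives 3640 nM
compound 3, `COc1ccc(/C=N/NC(=O)Nc2ccc(Oc3ccnc4[nH]ccc34)c(F)c2)cc1`, gives 3980 nM

Compound 1 carries the lowest of the three numbers, but a 1.5-fold higher number from compound 1 to compound 2 (0.16 log units; within the scatter) and a 1.6-fold higher number from compound 1 to compound 3 (0.20 log units; within the scatter) both fall within the scatter of repeated measurements, so none of the three can be told apart with confidence. The same holds for a 1.1-fold higher number from compound 2 to compound 3 (0.04 log units; within the scatter).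

The next compound to be measured is compound 4, `O=C(N/N=C/c1cc(Br)c(O)c(Br)c1)Nc1ccc(Oc2ccnc3[nH]ccc23)c(F)c1`. It differs from compound 1 in one place: 3,5-dibromo-4-hydroxyphenyl in place of phenyl on a carbon with a double bond to nitrogen. The steps already measured all concern the same phenyl ring and replace a hydrogen on it with a single group, and each stayed within the scatter. Among the measured compounds shown here, the change to compound 4 is larger in the sense that three groups enter at once, including one hydrogen-bond donor and one acceptor, yet nothing among the measured compounds points to a shift in either direction. The expectation for this assay is therefore no step beyond the scatter, with the range widened to allow for the bigger change. Compound 4 is estimated at 2800 nM, between 900 nM and 9000 nM, which means an expected step of a 1.1-fold higher number from compound 1 to compound 4 (0.05 log units; within the scatter).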

Compound 4, half-maximal inhibitory concentration: 16200 nM
Estimate against measurement, compound 4: 5.8-fold (0.76 log units) below, outside the stated range (above it).
By their numbers in this assay, from the lowest: compounds 1, 2 and 3 (each within the scatter of the next); then compound 4.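

Until now, swapping a hydrogen on this phenyl ring for nitro or methoxy gave steps within the scatter in this assay, so the position seemed to tolerate change. Among the compounds shown here, the 3,5-dibromo-4-hydroxyphenyl group is the first change here to go beyond the scatter, and it makes the compound a weaker inhibitor (a 6.5-fold higher number from compound 1 to compound 4 (0.81 log units; beyond the scatter)). Compound 4 also stands apart from the two substituted rings (a 4.1-fold higher number from compound 3 to compound 4 (0.61 log units; beyond the scatter); a 4.5-fold higher number from compound 2 to compound 4 (0.65 log units; beyond the scatter)), which makes it the weakest of the four and shows that the number at this position can move after all, though the size of the group that enters and its hydrogen-bonding count offer no explanation on their own, and no outside measurement bears on why the number rose.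

The new group brings two bromines and a hydroxyl at once, so the compounds shown do not tell which of them goes with the step; a phenyl ring carrying only the hydroxyl, or only the two bromines, would separate them. Also open, from the compounds shown here alone, is how this position responds to an amine or a carboxylic acid on the ring, or to a longer chain in place of the ring.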